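The source may hold more compounds than are shown below. What is called first, only, known or untested is meant among the compounds shown, and "the series" means these compounds.

Compound 1 `CCCCCCCCCCCCOC(=O)NC(=O)Oc1c(C(C)C)cccc1C(C)C` gives 21 nM in an assay on microsomes from intestine for inhibition of acyl-CoA:cholesterol acyltransferase (Oryctolagus cuniculus); a higher number here means a weaker inhibitor, a lower number a stronger inhibitor. Compound 2 `CCCCCCCCCCCCCCOC(=O)NC(=O)Oc1c(C(C)C)cccc1C(C)C` carries ethyl in place of hydrogen on a saturated chain carbon, ten or more bonds along the chain from an oxygen next to a carbonyl group and in this assay gives 10 nM, so a 2.1-fold lower number from compound 1 to compound 2 (0.32 log units; beyond the scatter). Compound 3 `CCCCCCCCC(C)OC(=O)NC(=O)Oc1c(C(C)C)cccc1C(C)C` rests on a different core, and how that core differs from the core of compound 1 is not broken down here; in this assay compound 3 gives 270 nM, the highest number of the three measured. Compound 4 `CCCCCCCCCCC(C)OC(=O)NC(=O)Oc1c(C(C)C)cccc1C(C)C` differs from compound 3 by ethyl in place of hydrogen on a saturated chain carbon, nine bonds along the chain from an oxygen next to a carbonyl group. The change from compound 1 to compound 2 and this one are the same kind of change, though not placed at the same point along the chain. Among the compounds with values here, for compound 4 a step of a 2.1-fold lower number from compound 3 to compound 4 (0.32 log units; beyond the scatter) is expected, because a 2.1-fold lower number from compound 1 to compound 2 (0.32 log units; beyond the scatter) gives the only measured guide. Compound 4 is therefore estimated at 130 nM in this assay, between 60 nM and 300 nM.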

Compound 4, half-maximal inhibitory concentration: 49 nM
Compound 4: the middle estimate sits 2.7-fold (0.42 log units) above what was measured; the measured number lies below the stated range.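

In this assay, ethyl in place of hydrogen gave a 5.5-fold lower number from compound 3 to compound 4 (0.74 log units; beyond the scatter), the same direction as the earlier step on the core of compound 1. Set side by side, the two steps cannot be told apart in size: the same change on two cores in this assay, a 2.1-fold lower number (0.32 log units; beyond the scatter) from compound 1 to compound 2 and a 5.5-fold lower number (0.74 log units; beyond the scatter) from compound 3 to compound 4, 2.6-fold (0.42 log units) apart, within the scatter of two such steps

The change therefore carried over in direction on these two cores, with no measurable difference in its size. This rests on a single pair per core, with the ethyl placed at different points along the chain, so it does not show that the step would hold on other cores or at other points.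

The compounds shown leave open whether a longer chain would continue the trend on either core. They also leave open how an amine or a carboxylic acid in place of the ethyl would read in this assay.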